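The source may hold more compounds than are shown below. What is called first, only, known or untested is meant among the compounds shown, and "the series" means these compounds.

Compound 1 `CNCC(=O)Nc1cc(OC)ccc1C(=O)c1ccc(OC)c2c1OC(C)(C)C=C2` and compound 2 `CNCC(=O)Nc1cc(OC)ccc1C(=O)c1ccc(OC)c2c1C=CC(C)(C)O2` share the same atoms joined differently; how their two cores differ is not broken down here. In a functional assay on A549 cells (Homo sapiens) for antiproliferative activity, read by MTT assay, with a stated time of 48 h (on this read-out higher numbers stand for weaker inhibition and lower numbers for stronger inhibition), compound 1 gives 620 nM, and compound 2 gives 1370 nM, a higher number that lies beyond the scatter. Compound 3 `CCNCC(=O)Nc1cc(OC)ccc1C(=O)c1ccc(OC)c2c1OC(C)(C)C=C2` carries the change methyl in place of hydrogen on a saturated chain carbon bound to an amine nitrogen on the core of compound 1, and in this assay compound 3 gives 1050 nM; the step is a 1.7-fold higher number from compound 1 to compound 3 (0.23 log units; within the scatter). Compound 4 `CCNCC(=O)Nc1cc(OC)ccc1C(=O)c1ccc(OC)c2c1C=CC(C)(C)O2` carries the same change, (methyl in place of hydrogen on a saturated chain carbon bound to an amine nitrogen), on the core of compound 2. Among the measured compounds shown here, the step from compound 2 to compound 4 is expected to be about a 1.5-fold higher number from compound 2 to compound 4 (0.19 log units; within the scatter), an expectation resting on the one measured example, a 1.7-fold higher number from compound 1 to compound 3 (0.23 log units; within the scatter). Compound 4 is therefore estimated at 2100 nM, expected to fall between 1000 nM and 4500 nM.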

Compound 4, half-maximal inhibitory concentration: 2310 nM
Estimate against measurement, compound 4: 1.1-fold (0.04 log units) below; the range from low to high includes it.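

In this assay, changing methylamino to ethylamino on the core of compound 2 gives a 1.7-fold higher number from compound 2 to compound 4 (0.23 log units; within the scatter), and the same change on the other core gives a step of matching size: the same change on two cores in this assay, a 1.7-fold higher number (0.23 log units; within the scatter) from compound 1 to compound 3 and a 1.7-fold higher number (0.23 log units; within the scatter) from compound 2 to compound 4, 1.0-fold (0.00 log units) apart, within the scatter of two such steps So the change carries over from one of these two cores to the other with no detectable difference in the size of its step. It does not show that ethylamino truly differs from methylamino, as each step alone lies within the scatter, and two cores cannot predict the result on a third.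

The compounds shown leave open what a longer chain, such as propylamino, would do at this place. The same question stands for a branched isopropylamino group or a dimethylamino group on either core.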